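Chloro in place of hydrogen on compound 2

The source may report more compounds than this note shows. Statements on the series, on what has been measured and on what is new or still open speak of the compounds shown alone.

Compound 1 `COc1ccc(-c2cnc(NC(=O)c3ccccc3C#N)n2C)cc1` and compound 2 `COc1ccc(-c2cnc(NC(=O)c3ccccc3)n2C)cc1` share a core and differ in one group. In a toxicity assay on THP-1 cells (Homo sapiens) for inhibition (on this read-out lower numbers stand for higher toxicity in this test and higher numbers for lower toxicity in this test), compound 1 gives > 100000 nM, which is a limit of the assay. Compound 2 gives > 100000 nM in this assay, also a limit and not a number, so compound 2 has no exact place in the series. Among the compounds with values here, the only measured step, a step that the two limits leave unreadable from compound 1 to compound 2, has no readable size. The evidence amounts to the limit of > 100000 nM in this assay, at which 2 of the 2 values shown sit.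

Compound 3 `COc1ccc(-c2cnc(NC(=O)c3cccc(Cl)c3)n2C)cc1` follows from compound 2 by chloro in place of hydrogen on an aromatic carbon. This is phenyl to 3-chlorophenyl, with the chloro meta to a large group. Within the data shown here, no measured step covers this change, and the step from cyano to hydrogen gives only the observation that both compounds sit at the limit. No step beyond the scatter is therefore expected in this assay, and a readable number could only be expected to fall toward higher toxicity. The expected step is a number no higher from compound 2 to compound 3 (the limit leaves the size open). Compound 3 is estimated at 100000 nM, with an expected range of 40000 nM to 200000 nM, and a report as a limit is the likeliest outcome.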

Compound 3, half-maximal cytotoxic concentration: > 28000 nM
Compound 3: only a limit was reported (the forecaster's own chance of this, stated with the estimate: 75%); the middle value does not contradict the limit.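

In this assay compound 3 gives > 28000 nM, which is a limit. Within the data shown here, the steps linking compound 3 to compound 1 and to compound 2 cannot be read, and no new step comes from this result. The compounds shown leave open whether chloro in place of hydrogen, or any other change on this phenyl, alters toxicity in this test at all.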